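The source may report more compounds than this note shows. Statements on the series, on what has been measured and on what is new or still open speak of the compounds shown alone.

Compound 1, `C#CCn1c2ccc([N+](=O)[O-])cc2c(=O)n1Cc1ccccc1`: in an ADME assay on L929 cells (Mus musculus) for cytotoxicity, read by resazurin assay, with a stated time of 48 h (a lower number here means that less compound is tolerated, a higher number that more compound is tolerated), compound 1 gives 195000 nM.
Compound 2, `COC(=O)CCn1c2ccc([N+](=O)[O-])cc2c(=O)n1Cc1ccccc1`: compound 2 reaches only the limit of > 256000 nM in this assay.
Compound 3, `COCCn1c2ccc([N+](=O)[O-])cc2c(=O)n1Cc1ccccc1`: compound 3 likewise reaches only the limit of > 256000 nM in this assay.

Compound 2 thus stands at the upper limit of this assay, and its number is a limit, not a measured value; (the limit of > 256000 nM in this assay, at which 2 of the 3 values shown sit). The measured steps around it are an at least 1.3-fold higher number from compound 1 to compound 2 (0.11 log units; that floor lies within the scatter) and an at least 1.3-fold higher number from compound 1 to compound 3 (0.11 log units; that floor lies within the scatter), both floors that lie within the scatter, while a step that the two limits leave unreadable from compound 2 to compound 3.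

Compound 4, `CCOC(=O)n1c2ccc([N+](=O)[O-])cc2c(=O)n1Cc1ccccc1`, has not yet been measured in this assay. It differs from compound 2 by ethoxycarbonyl in place of 2-(methoxycarbonyl)ethyl on an aromatic nitrogen. Among the measured compounds shown here, none of the measured steps alters the group on the aromatic nitrogen itself; the two readable steps concern the saturated chain carbon and were no larger than the scatter, and both limits sit at the same ceiling. On that basis the step from compound 2 to compound 4 is expected to be an at least 1.1-fold lower number from compound 2 to compound 4 (0.06 log units; that floor lies within the scatter), that is, no change beyond the scatter. Compound 4 is therefore estimated to give 220000 nM in this assay, within a range from 110000 nM to 400000 nM, with a fair chance that only a limit is reported again.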

Compound 4, concentration lethal to 50% of the cells: 122000 nM
Compound 4: middle estimate off by 1.8-fold (0.26 log units), on the high side; measured number inside the range.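

In this assay, the group on the aromatic nitrogen proves able to shift the read-out beyond the scatter, which the changes on the saturated chain carbon had not shown: ethoxycarbonyl in place of 2-(methoxycarbonyl)ethyl gives an at least 2.0-fold lower number from compound 2 to compound 4 (0.32 log units; beyond the scatter), and ethoxycarbonyl in place of 2-methoxyethyl gives an at least 2.0-fold lower number from compound 3 to compound 4 (0.32 log units; beyond the scatter). From the compounds shown here alone, both of these steps start from a limit and not from a measured number, so their true size stays unknown: the limit of > 256000 nM in this assay, at which 2 of the 4 values shown sit. Ethoxycarbonyl in place of propargyl gives a 1.6-fold lower number from compound 1 to compound 4 (0.20 log units; within the scatter), so at this position ethoxycarbonyl is set apart from the 2-(methoxycarbonyl)ethyl and 2-methoxyethyl groups but not from propargyl.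

The compounds shown leave open whether the step belongs to a carbonyl bound directly to the aromatic nitrogen or to the ethoxycarbonyl group as a whole, a question that an acetyl or a methoxycarbonyl group on that nitrogen could address. They also leave open how an amine or a carboxylic acid at the end of a longer chain on that nitrogen would read in this assay.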